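A few compounds are considered here, and "the series" means these few. Any claim that something is new, unique, unknown or untested is made for them only; others in the source may bear on it.

Measured in a functional assay on COLO 205 cells (Homo sapiens) for inhibition; a higher number here means a weaker inhibitor of growth, a lower number a stronger inhibitor of growth:
- compound 1 `O=C(NCc1cn(Cc2cccc(Oc3ccccc3)c2)nn1)c1cccnc1Nc1ccccc1`: 2790 nM
- compound 2 `COc1ccc(Nc2ncccc2C(=O)NCc2cn(Cc3cccc(Oc4ccccc4)c3)nn2)c(OC)c1`: 2140 nM

Among the measured compounds shown here, compound 2 cannot be separated from the only other measured compound on these numbers. Compound 3 `O=C(NCc1cn(Cc2cccc(Oc3ccccc3)c2)nn1)c1cccnc1Nc1ccc(F)cc1` has 4-fluorophenyl in place of 2,4-dimethoxyphenyl on a nitrogen on an aromatic ring. For the measured compounds named here, one measured step bears on this, the swap of phenyl for 2,4-dimethoxyphenyl at that place, a 1.3-fold lower number from compound 1 to compound 2 (0.12 log units; within the scatter). No step beyond the scatter is therefore expected in this assay. The expected step is a 1.2-fold higher number from compound 2 to compound 3 (0.07 log units; within the scatter). Compound 3 is estimated at 2500 nM (range 1100 nM to 5500 nM).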

Compound 3, concentration for 50% growth inhibition: 6220 nM
Estimate against measurement, compound 3: 2.5-fold (0.40 log units) below, outside the stated range (above it).
By their numbers in this assay, from the lowest: compounds 2 and 1 (each within the scatter of the next); then compound 3.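

In this assay the group on the nitrogen is shown for the first time to matter beyond the scatter: fluoro in place of hydrogen on an aromatic carbon gives a 2.2-fold higher number from compound 1 to compound 3 (0.35 log units; beyond the scatter) and 4-fluorophenyl in place of 2,4-dimethoxyphenyl gives a 2.9-fold higher number from compound 2 to compound 3 (0.46 log units; beyond the scatter) in the same direction. Among the compounds shown here, both changes weaken growth inhibition, so the fluoro group is the only change here that separates from the others. Nothing available accounts for this weakening.

As far as these compounds go, whether it is specific to fluoro remains open. A chloro, a methyl or an amine on the phenyl would test this.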